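From Pyrazole Amide Back to a Halogenated Phenyl Amide

A few compounds are considered here, and "the series" means these few. Any claim that something is new, unique, unknown or untested is made for them only; others in the source may bear on it.

Among the measured compounds shown here, compound 2 `CCC(=O)N1CCc2cc(CNC(=O)c3ccnn3C)ccc21` gives 14% in an assay on HEK293 cells for inhibition of Indoleamine 2,3-dioxygenase 1 (Homo sapiens), tested at 10 uM (a higher number here means more inhibition at the concentration tested (going by the name of the read-out), a lower number less inhibition), the lowest of the two numbers measured so far; its nearest neighbour, compound 1 `CCC(=O)N1CCc2cc(CNC(=O)c3cccc(F)c3)ccc21`, gives 82%. For the measured compounds named here, the one measured step, a number 68 percentage points lower from compound 1 to compound 2 (beyond the scatter), is the one that bears on the change now considered, since compound 3 `CCC(=O)N1CCc2cc(CNC(=O)c3cccc(Cl)c3)ccc21` carries 3-chlorophenyl in place of 1-methyl-1H-pyrazol-5-yl on a carbonyl carbon. This change largely reverses the earlier one: a phenyl ring bearing a halogen returns in place of the 1-methyl-1H-pyrazol-5-yl group, with chlorine now where compound 1 had fluorine. Because a number 68 percentage points lower from compound 1 to compound 2 (beyond the scatter) was a large fall, the return to a halogenated phenyl ring is expected to recover most of that loss in this assay. Compound 3 is therefore estimated at 75%, within 55% to 92%, which amounts to an expected step of a number 61 percentage points higher from compound 2 to compound 3 (beyond the scatter).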

Compound 3, a percentage reported as inhibition, at one concentration (the size of the read-out at that concentration, not a potency): 77%
Compound 3: middle estimate off by 2 percentage points, on the low side, and the stated range covers the measured number.
By their numbers in this assay, from the lowest: compound 2; then compounds 3 and 1 (each within the scatter of the next).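

In this assay, 3-chlorophenyl in place of 1-methyl-1H-pyrazol-5-yl on the carbonyl carbon gives a number 63 percentage points higher from compound 2 to compound 3 (beyond the scatter), so the large fall seen earlier at this position can be reversed. Chloro in place of fluoro on the aromatic carbon gives a number 5 percentage points lower from compound 1 to compound 3 (within the scatter), so this read-out does not separate the two halogens here. Among these three compounds, both halogenated phenyl amides give high numbers, and only the 1-methyl-1H-pyrazol-5-yl amide, compound 2, gives a low one.

No measurement at hand accounts for the gap between the phenyl and pyrazole amides. From the compounds shown here alone, it also remains open whether a phenyl ring without a halogen, or one carrying a methoxy group or an amine in place of the chlorine, would keep the number as high.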